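The compounds below may be only part of what the source reports. "The series", "measured", "known", "first", "only" and "open" are said of these compounds alone.

Working notes on the series. Within the data shown here, in an ADME assay on MT4 cells (Homo sapiens) for cytotoxicity, read by MTT assay, with a stated time of 5 days (on this read-out higher numbers stand for lower toxicity in this test and lower numbers for higher toxicity in this test), compound 1 `CCOC(=O)Cn1cc(CNC(=O)c2cnc(Nc3ccc(C#N)cc3)cc2Oc2c(C)cc(C)cc2C)nn1` gives 9530 nM and compound 2 `CCOC(=O)CCn1cc(CNC(=O)c2cnc(Nc3ccc(C#N)cc3)cc2Oc2c(C)cc(C)cc2C)nn1` gives 21500 nM; compound 2 holds the higher of the two numbers, the only step measured being a 2.3-fold higher number from compound 1 to compound 2 (0.35 log units; beyond the scatter). Compound 3 `Cc1cc(C)c(Oc2cc(Nc3ccc(C#N)cc3)ncc2C(=O)NCc2cn(CCCO)nn2)c(C)c1` differs from compound 2 by hydroxymethyl in place of ethoxycarbonyl on a saturated chain carbon, two bonds along the chain from an aromatic nitrogen. Among the measured compounds shown here, no measured step exchanges an ester for a hydroxyl; the one step known concerns chain length only, so for compound 3 in this assay no step beyond the scatter is expected, a 1.0-fold lower number from compound 2 to compound 3 (0.01 log units; within the scatter). The estimate for compound 3 is 21000 nM, within 8000 nM to 55000 nM.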

Compound 3, half-maximal cytotoxic concentration: 25200 nM
Compound 3: middle estimate off by 1.2-fold (0.08 log units), on the low side, and the stated range covers the measured number.
By their numbers in this assay, from the lowest: compound 1; then compounds 2 and 3 (each within the scatter of the next).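

In this assay the ester is not needed at this position: with hydroxymethyl in place of ethoxycarbonyl the change is a 1.2-fold higher number from compound 2 to compound 3 (0.07 log units; within the scatter), so the two end groups cannot be told apart here. With 2-hydroxyethyl in place of ethoxycarbonyl the change is a 2.6-fold higher number from compound 1 to compound 3 (0.42 log units; beyond the scatter), so the hydroxyl end also keeps the higher number that separated the longer ester from compound 1. No available evidence bears on the reason for either step. The compounds shown leave open how a carboxylic acid or an amine at the chain end would read, and whether a longer chain carrying the hydroxyl would hold the number of compound 3.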